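This account rests on a few compounds, and the source may have more. Where it says the series, first, only, none or still open, it means among the compounds named here.

Measured in a functional assay on MCF7 cells (Homo sapiens) for antiproliferative activity, read by MTT assay, with a stated time of 72 h; a lower number here means a stronger inhibitor, a higher number a weaker inhibitor:
- Compound 1 `O=C(N/N=C/c1ccc(F)cc1)Nc1ccc(Oc2ccnc3[nH]ccc23)c(F)c1` gives 800 nM
- Compound 2 `N#Cc1ccc(/C=N/NC(=O)Nc2ccc(Oc3ccnc4[nH]ccc34)c(F)c2)cc1` gives "not active" (no number reported)
- Compound 3 `O=C(N/N=C/c1ccc(F)cc1)Nc1ccc(Oc2ccnc3[nH]ccc23)cc1` gives 3720 nM

Compound 3, at 3720 nM, holds the higher of the two numbers reported, and compound 2 has no number. Compound 4 `COc1ccc(/C=N/NC(=O)Nc2ccc(Oc3ccnc4[nH]ccc34)cc2)cc1` differs from compound 3 by methoxy in place of fluoro on an aromatic carbon, para to a large group (methoxy in place of fluoro on an aromatic carbon). Going by the values given here, the only measured step, a 4.7-fold higher number from compound 1 to compound 3 (0.67 log units; beyond the scatter), is modest and concerns a different change elsewhere in the molecule, so it bears only indirectly. Among the compounds with values here, no measured step covers this exchange. In this assay, no step beyond the scatter is therefore expected, and no direction is favoured. The estimate is a 1.2-fold higher number from compound 3 to compound 4 (0.08 log units; within the scatter) as the expected step. For compound 4 the expected value is 4500 nM, with an estimated range of 1500 nM to 13000 nM.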

Compound 4, half-maximal inhibitory concentration: "not active" (no number reported)
Compound 4: no number reported, and the estimate cannot be compared.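

In this assay, going by these compounds alone, compound 4 is reported as not active, without a number, so no step from compound 3 to compound 4 can be read. No evidence on hand bears on this result.

The compounds shown leave open how far 4-fluorophenyl to 4-methoxyphenyl shifts activity in this series.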